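Replacing 4-iodophenyl with 3-nitrophenyl

The source may hold more compounds than are shown below. What is called first, only, known or untested is meant among the compounds shown, and "the series" means these compounds.

Measured in a functional assay on FM3A cells (Mus musculus) for antiproliferative activity; on this read-out lower numbers stand for stronger inhibition and higher numbers for weaker inhibition
- Compound 1 `COc1cc(C(=O)c2sc(-c3ccc(Br)cc3)cc2N)cc(OC)c1OC` gives 150 nM
- Compound 2 `COc1cc(C(=O)c2sc(-c3ccc(Cl)cc3)cc2N)cc(OC)c1OC` gives 90 nM
- Compound 3 `COc1cc(C(=O)c2sc(-c3ccc(I)cc3)cc2N)cc(OC)c1OC` gives 420 nM

Compound 3 has the highest of the three numbers, and its gaps to both other compounds lie beyond the scatter. Compound 4 `COc1cc(C(=O)c2sc(-c3cccc([N+](=O)[O-])c3)cc2N)cc(OC)c1OC` has not yet been measured. It carries 3-nitrophenyl in place of the 4-iodophenyl of compound 3, on an aromatic carbon next to the ring sulfur (3-nitrophenyl in place of 4-iodophenyl on an aromatic carbon). The measured steps that bear on this change only exchange one halogen for another. Two are modest (a 2.8-fold higher number from compound 1 to compound 3 (0.45 log units; beyond the scatter) and a 4.7-fold higher number from compound 2 to compound 3 (0.67 log units; beyond the scatter)) and one stays within the scatter (a 1.7-fold lower number from compound 1 to compound 2 (0.22 log units; within the scatter)). None of them brings in 3-nitrophenyl, so they offer only a rough size for a change at this place and leave the direction open. No shift beyond the scatter is therefore expected in this assay and the estimate stays wide. The step expected is a 1.4-fold lower number from compound 3 to compound 4 (0.15 log units; within the scatter) by estimate only. The estimated value for compound 4 is 300 nM (expected range 80 nM to 1200 nM).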

Compound 4, half-maximal inhibitory concentration: 17 nM
The estimate for compound 4 lay 18-fold (1.25 log units) above the measured number, and the stated range ends above it.
By their numbers in this assay, from the lowest: compound 4; then compounds 2 and 1 (each within the scatter of the next); then compound 3.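

In this assay, the group on the aromatic carbon next to the ring sulfur moves the number much further than the halogen exchanges alone showed: 3-nitrophenyl in place of 4-iodophenyl gives a 25-fold lower number from compound 3 to compound 4 (1.39 log units; beyond the scatter), and it also improves on the other two halogens, with a 5.3-fold lower number from compound 2 to compound 4 (0.72 log units; beyond the scatter) and an 8.8-fold lower number from compound 1 to compound 4 (0.95 log units; beyond the scatter). Compound 4 is therefore the most potent of the four, so this place accepts a group other than a 4-halophenyl and can gain from it. Nothing shown here explains the gain.

The step changes both the substituent and its place on the phenyl ring, and the compounds shown do not separate the two, which 4-nitrophenyl or 3-chlorophenyl could do. Going by these compounds, how an amine or a carboxylic acid on that phenyl ring would fare also remains open.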